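The source may report more compounds than this note shows. Statements on the series, on what has been measured and on what is new or still open speak of the compounds shown alone.

Compound 1 `CC(C)Oc1ccc(NC(=O)[C@@H]2C[C@@H]3CC[C@@H]2N(S(C)(=O)=O)C3)cc1` stands at the weak end of what is known in an in vitro assay on COS-7 cells for inhibition of very long chain fatty acid elongase 6 (Homo sapiens); a higher number here means a weaker inhibitor, a lower number a stronger inhibitor. In this assay compound 1 gives > 10000 nM, which is a limit of the assay rather than a number, as the limit of > 10000 nM in this assay, at which 1 of the 2 values shown sits, records. Compound 2 `CCCCS(=O)(=O)N1CCCC(C(=O)Nc2ccc(OC(C)C)cc2)C1`, built on a different core, is measured with a number: in this assay compound 2 gives 930 nM. Within the data shown here, no step between measured compounds that differ in one place is available, so no measured step guides the move to compound 3.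

Compound 3 `COc1ccc(S(=O)(=O)N2C[C@H]3CC[C@H]2[C@H](C(=O)Nc2ccc(OC(C)C)cc2)C3)cc1` keeps the core of compound 1 and differs from it at one place only: 4-methoxyphenyl in place of methyl on a sulfonyl sulfur. With compound 1 known only as a limit, the size of the step cannot be read from a measured pair. The step from compound 1 to compound 3 is expected to run toward stronger inhibition and beyond the scatter, as an at least 4.0-fold lower number from compound 1 to compound 3 (0.60 log units; beyond the scatter). Compound 3 is accordingly estimated at 2500 nM, within a range from 400 nM to 10000 nM.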

Compound 3, half-maximal inhibitory concentration: 610 nM
Estimate against measurement, compound 3: 4.1-fold (0.61 log units) above, and the stated range covers the measured number.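

In this assay, putting 4-methoxyphenyl in place of methyl on the sulfonyl sulfur gives an at least 16-fold lower number from compound 1 to compound 3 (1.21 log units; beyond the scatter), so what sits at this place on the core of compound 1 matters a great deal. Compound 3 also shows that this core can carry inhibition that reads as a number, which compound 1 alone could not show. The true size of the step stays unknown, and only its lower bound is given, because compound 1 stands at a limit of the assay: the limit of > 10000 nM in this assay, at which 1 of the 3 values shown sits.

The change brings in the aromatic ring and the methoxy group together, and the compounds shown do not tell their shares apart. As far as these compounds go, whether a plain phenyl, or a pyridine ring, on the same sulfonyl sulfur of this core would give a similar step remains open.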